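This account rests on a few compounds, and the source may have more. Where it says the series, first, only, none or still open, it means among the compounds named here.

In a functional assay on SK-OV-3 cells (Homo sapiens) for cytotoxicity (on this read-out higher numbers stand for weaker inhibition and lower numbers for stronger inhibition), compound 1 `C=C/C=C\[C@H](C)[C@H](OC(N)=O)[C@@H](C)[C@H](O)[C@@H](C)C/C(C)=C\[C@H](C)[C@@H](O)[C@@H](C)/C=C\CCc1cccc(O)c1C` gives 270 nM and compound 2 `C=C/C=C\[C@H](C)[C@H](OC(N)=O)[C@@H](C)[C@H](O)[C@@H](C)C/C(C)=C\[C@H](C)[C@@H](O)[C@@H](C)/C=C\CCc1cc(F)cc(F)c1` gives 360 nM, so these two cannot be told apart. Compound 3 `C=C/C=C\[C@H](C)[C@H](OC(N)=O)[C@@H](C)[C@H](O)[C@@H](C)C/C(C)=C\[C@H](C)[C@@H](O)[C@@H](C)/C=C\CCc1ccccc1` carries phenyl in place of 3,5-difluorophenyl on a saturated chain carbon, two bonds along the chain from a double-bonded chain carbon. For the measured compounds named here, the one measured step at this place is a 1.3-fold higher number from compound 1 to compound 2 (0.12 log units; within the scatter). Going by the values given here, with only that small step as a guide, no change beyond the scatter is expected in this assay. The expected step is a 1.2-fold lower number from compound 2 to compound 3 (0.08 log units; within the scatter). The estimate for compound 3 is 300 nM, with a range of 120 nM to 750 nM.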

Compound 3, half-maximal inhibitory concentration: 350 nM
For compound 3 the middle estimate is 1.2-fold (0.07 log units) below the measured one; the measured number falls inside the stated range.
By their numbers in this assay, from the lowest: compounds 1, 3 and 2 (each within the scatter of the next).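

In this assay the bare phenyl ring cannot be told apart from the 3,5-difluorophenyl ring, with a 1.0-fold lower number from compound 2 to compound 3 (0.01 log units; within the scatter) as the measure. The hydroxy and methyl groups on the ring of compound 1 also prove dispensable here, with a 1.3-fold higher number from compound 1 to compound 3 (0.11 log units; within the scatter) as the measure, so all three rings shown at this position fall within the scatter of one another. The compounds shown leave open whether an amine, a carboxylic acid or a longer chain in place of phenyl would move the number. No supporting evidence is available to explain why these rings read alike.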